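Cytotoxicity notes on compounds 1 to 4

A few compounds are considered here, and "the series" means these few. Any claim that something is new, unique, unknown or untested is made for them only; others in the source may bear on it.

Measured so far:
compound 1 `COC(=O)c1ccc(NCc2cncn2Cc2ccccc2Cl)cc1-c1ccccc1` — 10000 nM
compound 2 `COC(=O)c1ccc(NCc2cncn2Cc2ccccc2OC)cc1-c1ccccc1` — "not determined" (no result reported)
compound 3 `c1ccc(-c2ccc(Cn3cncc3CNc3ccc(-c4ccc[nH]4)c(-c4ccccc4)c3)cc2)cc1` — > 10000 nM

All three were run in a toxicity assay on NIH3T3 cells (Mus musculus) for cytotoxicity, read by resazurin assay; a higher number here means that more compound is needed for the effect, a lower number that less compound is needed. Compound 1 gives 10000 nM. For compound 2 the result is "not determined" (no result reported). Compound 3 gives > 10000 nM, which is a limit of the assay and not a number. Within the data shown here, compound 3 therefore stands only at a limit within this set, and compound 2 carries no single number either; the one piece of evidence on the values is the limit of > 10000 nM in this assay, at which 1 of the 3 values shown sits.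

Compound 4 `COC(=O)c1ccc(NCc2cncn2Cc2ccc(-c3ccccc3)cc2)cc1-c1ccccc1` has not yet been measured in this assay. It differs from compound 3 in one place: methoxycarbonyl in place of 1H-pyrrol-2-yl on an aromatic carbon. Compound 4 thus carries the methoxycarbonyl that compound 1 also carries, and compound 1 stands at 10000 nM in this assay. Among the measured compounds shown here, no step between measured compounds is available, so the size of the change cannot be read from the data; no step beyond the scatter is expected. The expected step is a number no higher from compound 3 to compound 4 (the limit leaves the size open). Compound 4 is estimated at 10000 nM, with a range from 3000 nM to 30000 nM, and a fair chance that only a limit is reported again.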

Compound 4, half-maximal effective concentration: > 1000 nM
Compound 4 gave a limit, no number; the forecaster's own chance of this, stated with the estimate: 50%; the middle value lies beyond the limit too.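

In this assay, among these compounds, compound 4 gives only a limit, so no step to compound 4 can be read from compound 3 or from compound 1. The compounds shown leave open whether methoxycarbonyl in place of 1H-pyrrol-2-yl, or 4-phenylphenyl in place of 2-chlorophenyl, changes the value at all.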